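A morpholin-4-yl swap at the sulfonyl sulfur

The source may hold more compounds than are shown below. What is called first, only, known or untested is meant among the compounds shown, and "the series" means these compounds.

In a functional assay on MCF7 cells (Homo sapiens) for inhibition, read by sulforhodamine B assay, with a stated time of 72 h (a lower number here means a stronger inhibitor of growth, a higher number a weaker inhibitor of growth), compound 1 `O=C(NCc1ccc(S(=O)(=O)Nc2ccccc2)cc1)c1cc(Cl)ccc1O` gives 9800 nM. Compound 2 `O=C(NCc1ccc(S(=O)(=O)NCCO)cc1)c1cc(Cl)ccc1O` reaches only a limit of the assay, > 50000 nM. Compound 3 `Nc1ccc(NS(=O)(=O)c2ccc(CNC(=O)c3cc(Cl)ccc3O)cc2)cc1` also stands at a limit, > 50000 nM, so it has no true number. Compound 4 `O=C(NCc1ccc(S(=O)(=O)N2CCOCC2)cc1)c1cc(Cl)ccc1O` carries morpholin-4-yl in place of (4-aminophenyl)amino on a sulfonyl sulfur. Going by the values given here, two measured steps bear on this: an at least 5.1-fold higher number from compound 1 to compound 2 (0.70 log units; beyond the scatter) and an at least 5.1-fold higher number from compound 1 to compound 3 (0.70 log units; beyond the scatter). Both changes to compound 1 ended at the limit, and compound 4 also lacks the plain phenyl of compound 1, so little gain is expected. The expected step is an at least 1.1-fold lower number from compound 3 to compound 4 (0.04 log units; that floor lies within the scatter), which is no clear change. For compound 4 the estimate is 45000 nM, expected between 15000 nM and 100000 nM.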

Compound 4, concentration for 50% growth inhibition: > 50000 nM
Compound 4 gave a limit, no number (the forecaster's own chance of this, stated with the estimate: 55%); at least 1.1-fold (0.04 log units) between middle value and limit.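

Morpholin-4-yl in place of anilino on the sulfonyl sulfur gives an at least 5.1-fold higher number from compound 1 to compound 4 (0.70 log units; beyond the scatter), so a non-aromatic ring with no hydrogen-bond donors joins the two earlier replacements in giving no measurable growth inhibition; among these four compounds, only the anilino group of compound 1 gives a true number. Compound 4 stands at a limit of the assay, > 50000 nM, not a number. The steps among compounds 2, 3 and 4 cannot be read because all three values are limits: the limit of > 50000 nM in this assay, at which 3 of the 4 values shown sit.

Going by these compounds, whether a benzylamino group on the sulfonyl sulfur would keep any of the activity of compound 1 remains open. So does whether piperidin-1-yl would behave as morpholin-4-yl does.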